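The source may hold more compounds than are shown below. What is called first, only, known or untested is meant among the compounds shown, and "the series" means these compounds.

Within the data shown here, compound 2 `CS(=O)(=O)Nc1cccc(-c2cc(C(O)(C(F)(F)F)C(F)(F)F)cnc2N2CCN(S(=O)(=O)c3ccc(N)nc3)CC2)c1` is the only compound here with a plain number in an ADME assay (liver) for metabolic stability, with Liver microsome (Homo sapiens) as the target, using microsomes and NADPH, with a stated time of 30 min, tested at 1 uM; on this read-out higher numbers stand for fast clearance and lower numbers for slow clearance: compound 2 gives 40 mL.min-1.g-1. The other measured compound, compound 1 `CC(C)(O)C#Cc1cc(C(O)(C(F)(F)F)C(F)(F)F)cnc1N1CCN(S(=O)(=O)c2ccc(N)nc2)CC1`, stands at a limit of this assay rather than at a number, and in this assay compound 1 gives < 14 mL.min-1.g-1. Among the measured compounds shown here, the single measured step, an at least 2.8-fold higher number from compound 1 to compound 2 (0.45 log units; beyond the scatter), points toward faster clearance, but its true size is known only as a lower bound because compound 1 sits at the limit of < 14 mL.min-1.g-1 in this assay, at which 1 of the 2 values shown sits.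

Compound 3 `COc1cncc(-c2cc(C(O)(C(F)(F)F)C(F)(F)F)cnc2N2CCN(S(=O)(=O)c3ccc(N)nc3)CC2)c1` differs from compound 2 in one place: 5-methoxypyridin-3-yl in place of 3-(methanesulfonamido)phenyl on an aromatic carbon. For the measured compounds named here, no measured step involves a 5-methoxypyridin-3-yl group, so the evidence is indirect: the 3-(methanesulfonamido)phenyl group that entered between compound 1 and compound 2 now leaves, while the group replacing it is itself aromatic and of similar size. A change no larger than modest is expected, most likely downward, and it may not rise beyond the scatter. For compound 3 the estimated value in this assay is 25 mL.min-1.g-1, with a likely range from 12 mL.min-1.g-1 to 55 mL.min-1.g-1. The expected step is therefore a 1.6-fold lower number from compound 2 to compound 3 (0.20 log units; within the scatter).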

Compound 3, intrinsic clearance in microsomes: 44 mL.min-1.g-1
For compound 3 the middle estimate is 1.8-fold (0.25 log units) below the measured one, within the range that was stated.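

In this assay, placing 5-methoxypyridin-3-yl on this aromatic carbon in place of 3-(methanesulfonamido)phenyl gives a 1.1-fold higher number from compound 2 to compound 3 (0.04 log units; within the scatter), so these two aromatic groups, which differ in their ring atoms and in size, cannot be told apart on this read-out. Replacing 3-hydroxy-3-methylbut-1-yn-1-yl with the new group gives an at least 3.1-fold higher number from compound 1 to compound 3 (0.49 log units; beyond the scatter), which points the same way as an at least 2.8-fold higher number from compound 1 to compound 2 (0.45 log units; beyond the scatter), so both aromatic groups shown at this position now stand on the side of faster clearance, where one example stood before. The true size of both of these steps remains a lower bound, since compound 1 sits at a limit of the assay and not at a number: the limit of < 14 mL.min-1.g-1 in this assay, at which 1 of the 3 values shown sits.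

The compounds shown cannot separate the effect of having an aromatic ring at this position from the effect of losing 3-hydroxy-3-methylbut-1-yn-1-yl. A plain phenyl ring, a morpholine joined through its nitrogen, or a short alkyne without the hydroxyl group would each help to show which part of these groups goes with the change in clearance.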